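The source may report more compounds than this note shows. Statements on the series, on what has been measured and on what is new or still open speak of the compounds shown alone.

Working notes on the oxadiazole series, cytotoxicity on liver-derived cells.

Compound 1 `Cc1ncc([N+](=O)[O-])n1CCSc1nnc(-c2ccc([N+](=O)[O-])cc2)o1` gives 4100 nM in a functional assay on HepG2 cells (Homo sapiens) for cytotoxicity, read by MTT assay, with a stated time of 48 h; on this read-out higher numbers stand for weaker inhibition and lower numbers for stronger inhibition. Compound 2 `Cc1ncc([N+](=O)[O-])n1CCSc1nnc(-c2ccc(Cl)cc2)o1` gives 7800 nM in this assay. Among the compounds with values here, the only measured step, chloro in place of nitro on an aromatic carbon, is a 1.9-fold higher number from compound 1 to compound 2 (0.28 log units; within the scatter); with two numbers so close, compound 2 cannot be separated from compound 1, and no ordering of the pair is claimed.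

Compound 3 `Cc1ncc([N+](=O)[O-])n1CCSc1nnc(-c2ccncc2)o1` is the next member and differs from compound 2 by pyridin-4-yl in place of 4-chlorophenyl on an aromatic carbon. Within the data shown here, the one measured step exchanges a substituent on the same six-membered ring that is now replaced as a whole, so it bears on the new step only loosely; all it shows is that a change at this end of the molecule moved this assay by no more than the scatter. No other comparison is available. For compound 3 a step of a 1.0-fold higher number from compound 2 to compound 3 (0.01 log units; within the scatter) is therefore expected, that is, nothing beyond the scatter, and the number for compound 3 in this assay is estimated at 8000 nM, with a range from 3500 nM to 18000 nM.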

Compound 3, half-maximal inhibitory concentration: 14800 nM
For compound 3 the middle estimate is 1.9-fold (0.27 log units) below the measured one, within the range that was stated.
By their numbers in this assay, from the lowest: compounds 1, 2 and 3 (each within the scatter of the next, the first and the last beyond it).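

In this assay the exchange of a whole ring at this aromatic carbon of the five-membered ring gives a 1.9-fold higher number from compound 2 to compound 3 (0.28 log units; within the scatter) so pyridin-4-yl in place of 4-chlorophenyl, with one hydrogen-bond acceptor entering, stays inside the scatter just as the substituent exchange did. The two ends of the series are a different matter: compound 1 gives 4100 nM and compound 3 gives 14800 nM in this assay, a gap beyond the scatter and the first difference at this position that is not lost in it, although each single step on the way remains within the scatter. No measurement in hand bears on what lies behind these numbers.

Going by these compounds, it remains open whether the number at this position would move further with a group of another kind, such as piperidin-4-yl or a phenyl ring carrying an amine or a carboxylic acid. On these data alone, it is equally open whether a longer chain between the two ring systems of the shared core would shift the number more than any change at this aromatic carbon has so far.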